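A few compounds are considered here, and "the series" means these few. Any claim that something is new, unique, unknown or untested is made for them only; others in the source may bear on it.

Measured so far:
compound 1: `COc1cccc(/C=C/C(=O)/C=C/c2ccc(OCc3cn(CCCCOc4cc(=O)oc5ccccc45)nn3)c(OC)c2)c1` — 44%
compound 2: `COc1cc(/C=C/C(=O)/C=C/c2cccs2)ccc1OCc1cn(CCCCCOc2cc(=O)oc3ccccc23)nn1` — 31%

Both numbers come from a functional assay on HCT-116 cells (Homo sapiens) for inhibition, read by sulforhodamine B assay, with a stated time of 48 h, tested at 50 uM; a higher number here means more inhibition of growth at the concentration tested, a lower number less inhibition of growth. Compound 1 stands highest of the two, and compound 2 sits a gap below it that is beyond the usual scatter of repeated measurements; compound 2 differs from compound 1 in more than one place, so that gap cannot be tied to any single change. Compound 3 is `COc1cc(/C=C/C(=O)/C=C/c2ccco2)ccc1OCc1cn(CCCCOc2cc(=O)oc3ccccc23)nn1` and has not yet been measured. It differs from compound 1 in one place only: furan-2-yl in place of 3-methoxyphenyl on a double-bonded chain carbon bound to a double-bonded chain carbon. Among the measured compounds shown here, no pair of measured compounds differs in just one place, so no directly measured step of this kind exists, and what can be said about compound 3 rests on the two numbers alone and on the change itself. A small drop from compound 1 is expected, a number 7 percentage points lower from compound 1 to compound 3 (within the scatter), likely within the scatter rather than beyond it. For compound 3 the estimated value in this assay is 37%, with a range from 22% to 52%.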

Compound 3, percent growth inhibition at one concentration: 47%
The estimate for compound 3 lay 10 percentage points below the measured number, and the stated range covers the measured number.
By their numbers in this assay, from the lowest: compound 2; then compounds 1 and 3 (each within the scatter of the next).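

In this assay, placing furan-2-yl in place of 3-methoxyphenyl on a double-bonded chain carbon bound to a double-bonded chain carbon gives a number 3 percentage points higher from compound 1 to compound 3 (within the scatter), the only step shown that isolates a change at this position. The group that leaves has 8 heavy atoms on a six-membered aromatic ring of carbon only, and the group that enters has 5 heavy atoms on a five-membered aromatic ring with 1 hetero atom, yet this read-out at a single concentration does not separate the two. Nothing measured here offers an explanation for this result.

As far as these compounds go, the two groups compared are both aromatic rings with no net charge and 1 hydrogen-bond acceptor each, so it remains open whether a group of a different kind at this position, such as a carboxylic acid or an amine, would also leave the number within the scatter. Compound 2 differs from compound 1 and from compound 3 in more than one place, so it cannot settle this question.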